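The source may report more compounds than this note shows. Statements on the series, on what has been measured and on what is new or still open speak of the compounds shown alone.

Measured so far:
- Compound 1, `O=C(COc1ccc(Oc2ccccc2)cc1)Cn1ncc2cc(NC(=O)Oc3ccccc3)ccc21`: in an assay on microsomes from brain for inhibition of Fatty-acid amide hydrolase 1 (Rattus norvegicus), read by fluorescence and HPLC, with a stated time of 45 min (a lower number here means a stronger inhibitor, a higher number a weaker inhibitor), compound 1 gives 2100 nM
- Compound 2, `O=C(COc1ccc(Oc2ccccc2)cc1)Cn1ncc2cc([N+](=O)[O-])ccc21`: in this assay compound 2 gives 550 nM

For the measured compounds named here, of these two numbers, compound 2 has the lower one, and its only neighbour is compound 1, which stands well clear of it: a 3.8-fold lower number from compound 1 to compound 2 (0.58 log units; beyond the scatter).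

Compound 3, `O=C(COc1ccc(Oc2ccccc2)cc1)Cn1ncc2cc(NC(=O)Nc3ccccc3)ccc21`, has not yet been measured. It comes from compound 2 by the change ((phenylcarbamoyl)amino in place of nitro on an aromatic carbon). Going by the values given here, this is close to the reverse of the one measured step, in which a carbamate-type group on the same aromatic carbon was exchanged for the nitro group and the number fell. Compound 3 carries a urea-type group at that position, which resembles the group of compound 1 more than the nitro group of compound 2, so the measured step points the other way here: the number is expected to rise again, by roughly the same amount, clearly beyond the scatter. The expected step is a 2.9-fold higher number from compound 2 to compound 3 (0.46 log units; beyond the scatter). For compound 3 the estimate is 1600 nM, with a range from 500 nM to 5000 nM.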

Compound 3, half-maximal inhibitory concentration: 6000 nM
Compound 3: middle estimate off by 3.8-fold (0.57 log units), on the low side; measured number above the stated range.
By their numbers in this assay, from the lowest: compound 2; then compound 1; then compound 3.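

In this assay, for the compounds shown here, this aromatic carbon of the shared core proves sensitive to what it carries: (phenylcarbamoyl)amino in place of nitro gives the largest step so far (an 11-fold higher number from compound 2 to compound 3 (1.04 log units; beyond the scatter)). Compound 1 had already shown a higher number than compound 2, but compound 3 shows that the two larger phenyl-bearing groups are not interchangeable, since one atom within the group matters: anilino in place of phenoxy on a carbonyl carbon gives a clear change (a 2.9-fold higher number from compound 1 to compound 3 (0.46 log units; beyond the scatter)). The three compounds thus rank by the group at this single carbon, yet no measurement shown here explains either step.

Still open, on these data alone, is which part of the two larger groups goes with the higher numbers, the terminal phenyl ring or the carbonyl unit that links it to the core, and a plain amine, an acetamide or a methyl urea at this carbon would help to separate the two. Also open, as far as these compounds go, is whether a substituent such as fluorine or methoxy on the terminal phenyl ring of compound 3 would move its number in either direction.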